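Replacing one aromatic group on a slowly cleared compound

The compounds below may be only part of what the source reports. "The series", "measured", "known", "first", "only" and "open" are said of these compounds alone.

Compound 1 `Cc1ccc2[nH]c(C(=O)N[C@H]3CN(S(=O)(=O)c4ccccc4)C[C@@H]3C(=O)NC[C@@H]3CCCN3C)cc2c1` gives 31 mL.min-1.g-1 in an ADME assay on microsomes from liver (Homo sapiens) for metabolic stability (on this read-out lower numbers stand for slow clearance and higher numbers for fast clearance), as a measured number. Compound 2 `Cc1ccc2[nH]c(C(=O)N[C@H]3CN(S(=O)(=O)c4ccccc4)C[C@@H]3C(=O)N[C@H]3CCCNC3)cc2c1` gives < 3 mL.min-1.g-1 in this assay as a limit and not a number. Compound 2 therefore stands at the limit of < 3 mL.min-1.g-1 in this assay, at which 1 of the 2 values shown sits, with no exact number. Compound 3 `Cc1csc(C(=O)N[C@H]2CN(S(=O)(=O)c3ccccc3)C[C@@H]2C(=O)N[C@H]2CCCNC2)n1` carries 4-methyl-1,3-thiazol-2-yl in place of 5-methyl-1H-indol-2-yl on a carbonyl carbon and is otherwise the same. Among the compounds with values here, the only measured step of an at least 10-fold lower number from compound 1 to compound 2 (1.01 log units; beyond the scatter) was large but lies elsewhere, on an amide-type nitrogen, so it offers little guidance here. The expected a number no lower from compound 2 to compound 3 (the limit leaves the size open) stays within the scatter in this assay with neither direction favoured. Compound 3 is estimated at 3 mL.min-1.g-1 with 1.5 mL.min-1.g-1 to 8 mL.min-1.g-1 as its expected range.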

Compound 3, intrinsic clearance in microsomes: 9.1 mL.min-1.g-1
Estimate against measurement, compound 3: 3.0-fold (0.48 log units) below; the whole stated range lies below it.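

In this assay, the group on the carbonyl carbon also counts, not only the group on the amide-type nitrogen: 4-methyl-1,3-thiazol-2-yl in place of 5-methyl-1H-indol-2-yl gives an at least 3.0-fold higher number from compound 2 to compound 3 (0.48 log units; beyond the scatter). Going by these compounds, compound 2 carries a limit and not a number, so the full size of this step stays unknown: the limit of < 3 mL.min-1.g-1 in this assay, at which 1 of the 3 values shown sits. The aromatic six-membered ring and the hydrogen-bond donor leave while sulfur enters, and one step cannot separate these changes.

Open, on these data alone, is how a phenyl ring or an unsubstituted 1,3-thiazol-2-yl would read on this carbonyl carbon. Also open, as far as these compounds go, is whether the thiazole change gives a similar step with (1-methylpyrrolidin-2-yl)methyl on the amide-type nitrogen.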